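Hydroxyl Returns to the Hydrazone Aryl Ring

This account rests on a few compounds, and the source may have more. Where it says the series, first, only, none or still open, it means among the compounds named here.

Compound 1, `Cc1c(C(=O)N/N=C\c2cccc(O)c2O)oc2cccc(O)c12`: in a functional assay on PC-3 cells (Homo sapiens) for inhibition (on this read-out higher numbers stand for weaker inhibition and lower numbers for stronger inhibition), compound 1 gives 12200 nM.
Compound 2, `Cc1c(C(=O)N/N=C\c2cccnc2)oc2cccc(O)c12`: in this assay compound 2 reaches only the limit >= 40000 nM.
Compound 3, `Cc1c(C(=O)N/N=C\c2ccc(F)cc2)oc2cccc(O)c12`: in this assay compound 3 reaches only the limit >= 40000 nM.

Compound 3 thus sits at the limit, as noted in the limit of >= 40000 nM in this assay, at which 2 of the 3 values shown sit, and cannot be ranked against compound 2. Compound 4, `Cc1c(C(=O)N/N=C\c2cccc(Br)c2O)oc2cccc(O)c12`, differs from it by 3-bromo-2-hydroxyphenyl in place of 4-fluorophenyl on a carbon with a double bond to nitrogen. The step of an at least 3.2-fold higher number from compound 1 to compound 3 (0.51 log units; beyond the scatter) is the relevant comparison: it ran from a ring bearing hydroxyls to a bare fluorophenyl and weakened inhibition at least modestly. The new change restores a hydroxyl, so a step back toward compound 1 is expected, of size an at least 2.6-fold lower number from compound 3 to compound 4 (0.42 log units; beyond the scatter). Compound 4 is expected to give about 15000 nM, between 5000 nM and 40000 nM.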

Compound 4, half-maximal inhibitory concentration: 16600 nM
Compound 4: middle estimate off by 1.1-fold (0.04 log units), on the low side, and the stated range covers the measured number.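

In this assay, 3-bromo-2-hydroxyphenyl on the carbon with a double bond to nitrogen gives a number clear of the limit, with an at least 2.4-fold lower number from compound 3 to compound 4 (0.38 log units; beyond the scatter) and an at least 2.4-fold lower number from compound 2 to compound 4 (0.38 log units; beyond the scatter). These two steps give only a minimum size, as the starting values are limits: the limit of >= 40000 nM in this assay, at which 2 of the 4 values shown sit. Bromo in place of hydroxy on an aromatic carbon leaves the read-out within the scatter, with a 1.4-fold higher number from compound 1 to compound 4 (0.13 log units; within the scatter), so a second ring hydroxy is not required for this level of inhibition.

The compounds shown do not separate the contribution of the remaining hydroxy from that of the bromo. On these data alone, how a methoxy group or an amine in place of that hydroxy would read also stays open.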